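Working notes: from compound 2 to compound 4

The source may hold more compounds than are shown below. What is called first, only, known or untested is meant among the compounds shown, and "the series" means these compounds.

Measured so far in a functional assay on 786-0 cells (Homo sapiens) for inhibition, read by sulforhodamine B assay, with a stated time of 48 h; a lower number here means a stronger inhibitor of growth, a higher number a weaker inhibitor of growth:
- compound 1 `COc1ccc(NC(=O)Nc2n[nH]c3ccccc23)cc1`: > 100000 nM
- compound 2 `CCCCOc1ccc(NC(=O)n2nc(N)c3ccccc32)cc1`: 21000 nM
- compound 3 `Nc1nn(C(=O)Nc2c(F)cccc2F)c2ccccc12`: < 100000 nM

Among the compounds with values here, compound 2 stands alone: in this assay compound 2 gives 21000 nM, the only plain number among the three measured compounds. For compound 1 this assay reports only a limit, > 100000 nM, which is the limit of > 100000 nM in this assay, at which 1 of the 3 values shown sits. For compound 3 this assay reports only a limit, < 100000 nM, which is the limit of < 100000 nM in this assay, at which 1 of the 3 values shown sits. Within the data shown here, no two measured compounds differ in one place, so no measured step is available to calibrate a structural change.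

Compound 4 `Nc1nn(C(=O)Nc2ccc(Cc3ccccc3)cc2)c2ccccc12` is not yet measured. It differs from compound 2 by benzyl in place of butoxy on an aromatic carbon. Among the measured compounds shown here, with no measured step to lean on, the change is expected to stay within the scatter, i.e. an expected step of a 1.3-fold lower number from compound 2 to compound 4 (0.12 log units; within the scatter) in this assay. Compound 4 is therefore estimated at 16000 nM in this assay, with an expected range from 4000 nM to 60000 nM.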

Compound 4, concentration for 50% growth inhibition: 3760 nM
Estimate against measurement, compound 4: 4.3-fold (0.63 log units) above; the measured number lies below the stated range.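

In this assay, within the data shown here, the step of a 5.6-fold lower number from compound 2 to compound 4 (0.75 log units; beyond the scatter) is the first measured step, and it shows that the result depends on the group held on this aromatic carbon, para to a large group. Benzyl, with its six-membered aromatic ring of carbon only, is tolerated there in place of butoxy, which has no ring, and the number moves to stronger growth inhibition rather than weaker. Nothing measured here accounts for this single step.

From the compounds shown here alone, the change replaces a chain with a ring and removes the oxygen in one move, so the contribution of each remains open. A phenoxy group, which keeps the ring and the oxygen, and a cyclohexylmethyl group, which keeps the carbon link without an aromatic ring, would separate these contributions at the same place.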